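A methoxy added to the core of compound 1

The source may hold more compounds than are shown below. What is called first, only, known or untested is meant among the compounds shown, and "the series" means these compounds.

Compound 1 `C#CCOc1cccc(/C=C/C(=O)Nc2cc(C(=O)c3cc(OC)c(OC)c(OC)c3)ccc2OC)c1` and compound 2 `COc1ccc(C(=O)c2cc(OC)c(OC)c(OC)c2)cc1NC(=O)/C=C/c1ccc(F)c(F)c1` share one core and were both tested in a functional assay on HeLa cells (Homo sapiens) for cytotoxicity, read by MTT assay, with a stated time of 72 h; a lower number here means a stronger inhibitor, a higher number a weaker inhibitor. There compound 1 gives 14000 nM, while compound 2 gives 8100 nM; the step of a 1.7-fold lower number from compound 1 to compound 2 (0.24 log units; within the scatter) stays within the scatter. Compound 3 `C#CCOc1cccc(/C=C/C(=O)Nc2cc(C(=O)c3cc(OC)c(OC)c(OC)c3)cc(OC)c2OC)c1` differs from compound 1 by methoxy in place of hydrogen on an aromatic carbon. Going by the values given here, no measured step touches this change, since the only step known concerns the other end of the molecule. Compound 3 is therefore expected to show no shift beyond the scatter, a step of no change at the digits printed from compound 1 to compound 3 (within the scatter). Compound 3 is estimated at 14000 nM, within 5000 nM to 40000 nM.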

Compound 3, half-maximal inhibitory concentration: 7300 nM
The estimate for compound 3 lay 1.9-fold (0.28 log units) above the measured number; the range from low to high includes it.
By their numbers in this assay, from the lowest: compounds 3, 2 and 1 (each within the scatter of the next).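

In this assay, methoxy in place of hydrogen on an aromatic carbon, ortho to a methoxy group, gives a 1.9-fold lower number from compound 1 to compound 3 (0.28 log units; within the scatter). The earlier step concerned only the other end of the molecule, whereas this one shows that the shared core accepts this added methoxy without a shift beyond the scatter. Nothing available explains this result.

The compounds shown leave open whether an amine, a hydroxyl or a longer ether chain at this position would also stay within the scatter. As far as these compounds go, it also remains open whether the added methoxy would behave the same way alongside the 3,4-difluorophenyl of compound 2.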